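Propoxy amine ring swap in the triazole carboxamide series

The source may report more compounds than this note shows. Statements on the series, on what has been measured and on what is new or still open speak of the compounds shown alone.

The series shares one core, a methoxy-quinoline ether carrying a fluorinated anilide of a triazole carboxylic acid, with an amine hung on a three-carbon chain from the second quinoline oxygen. Compound 1 `COc1cc2c(Oc3ccc(NC(=O)c4nnn(-c5ccccc5C(F)(F)F)c4C)cc3F)ccnc2cc1OCCCN1CCCC1`, compound 2 `COc1cc2c(Oc3ccc(NC(=O)c4nnn(-c5ccc(C)cc5)c4C(F)(F)F)cc3F)ccnc2cc1OCCCN1CCCC1` and compound 3 `COc1cc2c(Oc3ccc(NC(=O)c4nnn(-c5ccccc5C(F)(F)F)c4C(F)(F)F)cc3F)ccnc2cc1OCCCN1CCCC1` differ only on the triazole and its pendant aryl ring. In a functional assay on U-87MG ATCC cells (Homo sapiens) for cytotoxicity, read by MTT assay, with a stated time of 72 h (on this read-out higher numbers stand for weaker inhibition and lower numbers for stronger inhibition), compound 1 gives 1060 nM. Compound 2 gives "not determined" (no result reported) in this assay. Within the data shown here, compound 3 gives 1180 nM; the only other number, that of compound 1, lies within the scatter of it. Among the measured compounds shown here, the single measured step, a 1.1-fold higher number from compound 1 to compound 3 (0.05 log units; within the scatter), concerns the triazole substituent and leaves the amine end untouched.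

Compound 4 `COc1cc2c(Oc3ccc(NC(=O)c4nnn(-c5ccccc5C(F)(F)F)c4C(F)(F)F)cc3F)ccnc2cc1OCCCN1CCC(C)CC1` is the next entry. The change is 4-methylpiperidin-1-yl in place of pyrrolidin-1-yl on a saturated chain carbon, three bonds along the chain from an oxygen on an aromatic ring. For the measured compounds named here, no measured pair in the set alters this amine ring, so nothing here speaks to its effect in either direction; the one step that exists, from compound 1 to compound 3, sits elsewhere in the molecule and was itself flat. The expected step is therefore a 1.0-fold higher number from compound 3 to compound 4 (0.01 log units; within the scatter), meaning none beyond the scatter. Compound 4 is estimated at 1200 nM in this assay, with a range from 450 nM to 3200 nM.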

Compound 4, half-maximal inhibitory concentration: 1240 nM
The estimate for compound 4 lay 1.0-fold (0.01 log units) below the measured number; measured number inside the range.
By their numbers in this assay, from the lowest: compounds 1, 3 and 4 (each within the scatter of the next).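

Among these compounds, at the amine end of the chain, 4-methylpiperidin-1-yl in place of pyrrolidin-1-yl gives the first reading for this position in this assay, and the step is a 1.1-fold higher number from compound 3 to compound 4 (0.02 log units; within the scatter) with the six-membered ring and its 7 heavy atoms leaving the number inside the scatter. Taken with a 1.1-fold higher number from compound 1 to compound 3 (0.05 log units; within the scatter) on the triazole, this means that neither the amine ring nor the triazole substituent has so far moved the number beyond the scatter across compounds 1, 3 and 4, while the steps to compound 2 cannot be read as it has no number. Nothing measured offers an explanation for this flat response at the amine end.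

This single step changes ring size and adds the methyl at once, so the separate contribution of each remains unresolved, and piperidin-1-yl at the same place would divide the two. Also open, from the compounds shown here alone, is whether morpholin-4-yl, 4-methylpiperazin-1-yl or a dimethylamino group on the same chain, or a four-carbon chain in place of 3-(pyrrolidin-1-yl)propyl, would give a step beyond the scatter.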